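The source may hold more compounds than are shown below. What is called first, only, known or untested is meant among the compounds shown, and "the series" means these compounds.

Measured so far in an assay on blood with Thromboxane-A synthase (Homo sapiens) as the target; a lower number here means a stronger inhibitor, a higher number a weaker inhibitor:

Compound 1, `O=C(O)CCc1c(-c2cccnc2)ccc2c1CCC(NS(=O)(=O)c1ccc(Cl)cc1)C2`: in this assay compound 1 gives only a limit, > 10000 nM.
Compound 2, `O=C(O)CCc1cc(Cc2cccnc2)cc2c1CCC(NS(=O)(=O)c1ccc(Cl)cc1)C2`: in this assay compound 2 gives 1100 nM.
Compound 3, `O=C(O)CC/C=C/c1c(Cc2cccnc2)ccc2c1CCC(NS(=O)(=O)c1ccc(Cl)cc1)C2`: in this assay compound 3 gives 1400 nM.

Compound 3 and compound 2 sit within the scatter of one another, so the two numbers say nothing about a difference between them. The value of compound 1 is a limit and not a number; this is the limit of > 10000 nM in this assay, at which 1 of the 3 values shown sits.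

Compound 4, `O=C(O)CCC/C=C/c1c(Cc2cccnc2)ccc2c1CCC(NS(=O)(=O)c1ccc(Cl)cc1)C2`, is not yet measured. The change from compound 3 to compound 4 is carboxymethyl in place of carboxy on a saturated chain carbon, two bonds along the chain from a double-bonded chain carbon. The acid chain of compound 4 thus runs one carbon longer than that of compound 3.

Among the compounds with values here, no step between two measured compounds of this kind is available, so the expectation rests only on the spread seen. In this assay compound 4 is expected to stay close to compound 3, with a step of a 1.4-fold higher number from compound 3 to compound 4 (0.15 log units; within the scatter) that is not expected to reach clearly beyond the scatter. The estimate for compound 4 in this assay is 2000 nM, within 700 nM to 6000 nM.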

Compound 4, half-maximal inhibitory concentration: 1100 nM
Estimate against measurement, compound 4: 1.8-fold (0.26 log units) above; the measured number falls inside the stated range.
By their numbers in this assay, from the lowest: compounds 2, 4 and 3 (each within the scatter of the next). At a limit, above all of these: compound 1.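

Going from 4-carboxybut-1-en-1-yl to 5-carboxypent-1-en-1-yl gives the first step in the series between compounds that differ in one place: in this assay, a 1.3-fold lower number from compound 3 to compound 4 (0.10 log units; within the scatter). On a saturated chain carbon, two bonds along the chain from a double-bonded chain carbon, the assay therefore does not separate carboxymethyl from carboxy, and these two chain lengths cannot be told apart by their numbers. Two compounds give no trend with chain length, and no measured property available here bears on this step.

Open, going by these compounds, is whether an acid chain longer than 5-carboxypent-1-en-1-yl, or one shorter than 4-carboxybut-1-en-1-yl, would stay within the scatter of these two compounds or move clearly away from them. Also open is how a saturated chain in place of the double bond, or a tetrazole or a primary amide in place of the carboxylic acid, would read in this assay on the same core, since every compound shown carries a carboxylic acid.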